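From Chloro to Fluoro in a Cytotoxicity Series

The compounds below may be only part of what the source reports. "The series", "measured", "known", "first", "only" and "open" are said of these compounds alone.

In a functional assay on A549 cells (Homo sapiens) for cytotoxicity, read by MTT assay, with a stated time of 72 h (on this read-out lower numbers stand for stronger inhibition and higher numbers for weaker inhibition), compound 1 `CCN(CC)Cc1ccc2nc(NC(=O)N/N=C/c3cn(Cc4ccc(C(C)(C)C)cc4)c4ccccc34)sc2c1` gives 1710 nM and compound 2 `CN(C)Cc1ccc2nc(NC(=O)N/N=C3\C(=O)Nc4ccc(Cl)cc43)sc2c1` gives 3180 nM. Among the measured compounds shown here, these two values lie within the usual scatter of each other, so compound 2 stands level with compound 1 on the only numbers available, and the pair offers no ranking. The next compound, compound 3 `CN(C)Cc1ccc2nc(NC(=O)N/N=C3\C(=O)Nc4ccc(F)cc43)sc2c1`, keeps the core of compound 2 and carries a single change, fluoro in place of chloro on an aromatic carbon. For the measured compounds named here, no two measured compounds differ in one place only, so no measured step is available as a guide. For this small exchange, no shift beyond the scatter is expected in this assay, and the estimated change is a 1.3-fold higher number from compound 2 to compound 3 (0.10 log units; within the scatter). For compound 3 the expected value is 4000 nM, with an estimated range of 1500 nM to 10000 nM.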

Compound 3, half-maximal inhibitory concentration: 2310 nM
Estimate against measurement, compound 3: 1.7-fold (0.24 log units) above; measured number inside the range.
By their numbers in this assay, from the lowest: compounds 1, 3 and 2 (each within the scatter of the next).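

In this assay, among the compounds shown here, the exchange of chloro for fluoro gives the first step that differs in one place only: a 1.4-fold lower number from compound 2 to compound 3 (0.14 log units; within the scatter). At this place on the six-membered aromatic ring of carbon only, the two halogens therefore cannot be told apart in this read-out, which is something compounds 1 and 2 could not show, since they differ in more than one place. Nothing measured here offers an explanation for this result.

The compounds shown leave open whether hydrogen, bromo, methyl or methoxy at this place would also stay within the scatter of compound 2. Going by these compounds, it also remains open whether a larger change here, such as an amine or a carboxylic acid, would move the number beyond the scatter at all.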